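The source may hold more compounds than are shown below. What is called first, only, known or untested is meant among the compounds shown, and "the series" means these compounds.

Measured so far:

Compound 1 `O=S(=O)(Nc1ccc(-c2nc3ccccc3o2)cc1)c1cccc(F)c1`: in an assay on isolated protein for inhibition of malate dehydrogenase, mitochondrial (Sus scrofa), with stated times of 45 min and 30 min (a higher number here means a weaker inhibitor, a lower number a stronger inhibitor), compound 1 gives > 63000 nM, which is a limit of the assay and not a number.
Compound 2 `O=S(=O)(Nc1ccc2oc(-c3ccccc3)nc2c1)c1cccc(C(F)(F)F)c1`: in this assay compound 2 gives > 63000 nM, again a limit rather than a number.
Compound 3 `O=S(=O)(Nc1ccc(-c2nc3ccccc3o2)cc1)c1ccc(Cl)c(C(F)(F)F)c1`: in this assay compound 3 gives > 63000 nM, also a limit rather than a number.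

Compound 1 therefore cannot be placed anywhere on these numbers: its own result is a limit, and the other two results are limits as well, so none of the three can be ordered against another. This is summed up in the limit of > 63000 nM in this assay, at which 3 of the 3 values shown sit. Compound 4 `Cc1ccc(S(=O)(=O)Nc2ccc(-c3nc4ccccc4o3)cc2)cc1` differs from compound 1 in a single place: 4-methylphenyl in place of 3-fluorophenyl on a sulfonyl sulfur. Among the measured compounds shown here, no two measured compounds here differ in only one place, so there is no measured step to lean on. Because the limit of > 63000 nM in this assay, at which 3 of the 3 values shown sit, puts every measured compound at the same limit, compound 4 is expected to stay there as well. The step that the limit leaves unreadable from compound 1 to compound 4 is expected to be none beyond the scatter. Compound 4 is estimated at 100000 nM, with a range from 40000 nM to 300000 nM.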

Compound 4, half-maximal inhibitory concentration: > 63000 nM
Compound 4 ended at the assay's limit; the forecaster's own chance of this, stated with the estimate: 85%; the middle value does not contradict the limit.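

Compound 1 and compound 4 both end at a limit rather than a number, so the step between them cannot be read: the limit of > 63000 nM in this assay, at which 4 of the 4 values shown sit.

The compounds shown leave open how far each one lies beyond that limit, and which change to the shared core, if any, would give a true number in this assay.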